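Acyl variation on the ring nitrogen of bis-benzylidene piperidinones

A few compounds are considered here, and "the series" means these few. Any claim that something is new, unique, unknown or untested is made for them only; others in the source may bear on it.

Measured so far:
compound 1 `COc1cc(/C=C2\CN(C)C/C(=C\c3cc(OC)c(OC)c(OC)c3)C2=O)cc(OC)c1OC` — 1000 nM
compound 2 `CCC(=O)N1C/C(=C\c2cc(OC)c(OC)c(OC)c2)C(=O)/C(=C/c2cc(OC)c(OC)c(OC)c2)C1` — 1700 nM

For the measured compounds named here, in a functional assay on NCI-H1975 cells (Homo sapiens) for cytotoxicity, read by MTT assay, with a stated time of 72 h (on this read-out lower numbers stand for stronger inhibition and higher numbers for weaker inhibition), compound 2 gives 1700 nM, the highest of the two numbers so far; its nearest neighbour is compound 1 at 1000 nM. Going by the values given here, the one measured step, a 1.7-fold higher number from compound 1 to compound 2 (0.23 log units; within the scatter), arises from propanoyl in place of methyl on the ring nitrogen and stays within the scatter.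

Compound 3 `COc1cc(/C=C2\CN(C(=O)C(C)C)C/C(=C\c3cc(OC)c(OC)c(OC)c3)C2=O)cc(OC)c1OC` keeps the acyl nitrogen of compound 2 and differs only by methyl in place of hydrogen on a saturated chain carbon bound to a carbonyl carbon and a saturated chain carbon. Among the compounds with values here, the single step that bears on this position, a 1.7-fold higher number from compound 1 to compound 2 (0.23 log units; within the scatter), was small for a far larger change at the same nitrogen, so a further methyl on the acyl chain is expected to move the number little, if at all, beyond the scatter. The expected step is a 1.1-fold higher number from compound 2 to compound 3 (0.05 log units; within the scatter). Compound 3 is therefore estimated at 1900 nM, with a range from 900 nM to 4000 nM.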

Compound 3, half-maximal inhibitory concentration: 1900 nM
Compound 3: middle estimate and measured number agree at the digits printed; the measured number falls inside the stated range.
By their numbers in this assay, from the lowest: compounds 1, 2 and 3 (each within the scatter of the next).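

In this assay, methyl in place of hydrogen on a saturated chain carbon bound to a carbonyl carbon and a saturated chain carbon gives a 1.1-fold higher number from compound 2 to compound 3 (0.05 log units; within the scatter) and so leaves this acyl chain position unresolved between propanoyl and isopropylcarbonyl. Measured against the methyl of compound 1, isopropylcarbonyl gives a 1.9-fold higher number from compound 1 to compound 3 (0.28 log units; within the scatter) in this assay and, like propanoyl, stays within the scatter, so the three nitrogen substituents shown cannot be told apart on this read-out. No measured evidence bears on why this position behaves as it does.

On these data alone, whether a longer acyl chain, a benzoyl group or an acyl chain carrying an amine or a carboxylic acid would separate from these three remains open. As far as these compounds go, all three compounds share the rest of the core, so the effect of a change elsewhere, such as a hydroxyl in place of a methoxy group, is also open.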